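Replacing Furan-3-yl with 2-Fluorophenyl on a Shared Core

The source may hold more compounds than are shown below. What is called first, only, known or untested is meant among the compounds shown, and "the series" means these compounds.

In a functional assay on THP-1 cells (Homo sapiens) for inhibition, read by ELISA, with stated times of 1 h and 18 h (on this read-out higher numbers stand for weaker inhibition and lower numbers for stronger inhibition), compound 1 `NC(=O)[C@@H]1[C@H](Nc2nc(Nc3ccc(C(=O)N4CCCC4)cc3)ncc2-c2cccnc2)[C@H]2C=C[C@@H]1C2` gives 230 nM, compound 2 `NC(=O)[C@@H]1[C@H](Nc2nc(Nc3cccc(C(=O)N4CCCC4)c3)ncc2C2CC2)[C@H]2C=C[C@@H]1C2` gives 90 nM and compound 3 `NC(=O)[C@@H]1[C@H](Nc2nc(Nc3cccc(C(=O)N4CCCC4)c3)ncc2-c2ccoc2)[C@H]2C=C[C@@H]1C2` gives 40 nM. Compound 3 therefore has the lowest number of the three, which makes it the strongest inhibitor measured so far.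

The next compound is compound 4 `NC(=O)[C@@H]1[C@H](Nc2nc(Nc3cccc(C(=O)N4CCCC4)c3)ncc2-c2ccccc2F)[C@H]2C=C[C@@H]1C2`. It keeps the rest of compound 3 but has 2-fluorophenyl in place of furan-3-yl on an aromatic carbon.

Among the measured compounds shown here, only one measured step bears on this place: a 2.3-fold lower number from compound 2 to compound 3 (0.35 log units; beyond the scatter), with furan-3-yl in place of cyclopropyl. That step is modest but beyond the scatter, so the number does respond to the group placed here. Compound 1 differs from compound 3 in more than this one group, so it offers no clean comparison. For the measured compounds named here, no measured compound carries 2-fluorophenyl, which leaves the size of the next step uncertain. Since compound 3 already has the lowest number, a modest rise seems more likely than a further fall.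

The expected change is a 2.0-fold higher number from compound 3 to compound 4 (0.30 log units; within the scatter). Compound 4 is therefore estimated at 80 nM, with an expected range of 25 nM to 250 nM.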

Compound 4, half-maximal inhibitory concentration: 130 nM
Estimate against measurement, compound 4: 1.6-fold (0.21 log units) below, and the stated range covers the measured number.
By their numbers in this assay, from the lowest: compound 3; then compounds 2, 4 and 1 (each within the scatter of the next, the first and the last beyond it).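

In this assay, the position on the six-membered aromatic ring with 2 nitrogen accepts a larger aromatic group, but the change costs inhibition: a 3.3-fold higher number from compound 3 to compound 4 (0.51 log units; beyond the scatter), so furan-3-yl holds an edge over 2-fluorophenyl that lies beyond the scatter. Set against cyclopropyl, 2-fluorophenyl gives a 1.4-fold higher number from compound 2 to compound 4 (0.16 log units; within the scatter), which lies within the scatter, so an aromatic ring at this place does not by itself lower the number, and of these two aromatic groups only furan-3-yl stands apart from cyclopropyl. Furan-3-yl and 2-fluorophenyl differ at once in ring size, in hetero atom and in hydrogen-bond acceptor count, and no data are available to say which of these differences, if any, accounts for the step.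

One open question is what the fluorine contributes, which a plain phenyl group at this place could answer. Another is whether the oxygen of furan-3-yl matters, which thiophen-3-yl, carrying sulfur in that ring in place of oxygen, could help to settle.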